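The source may hold more compounds than are shown below. What is called first, only, known or untested is meant among the compounds shown, and "the series" means these compounds.

Measured compounds in a functional assay on CHO cells for antagonist activity at Glucagon receptor (Homo sapiens), read by cAMP accumulation, with stated times of 30 min and 45 min; a lower number here means a stronger inhibitor, a higher number a weaker inhibitor:

- compound 1 `CC(C)(C)[C@H]1CC[C@]2(CC1)N=C(c1cccc(C(F)(F)F)c1)C(=O)N2Cc1ccc(C(=O)NCCC(=O)O)cc1` gives 510 nM
- compound 2 `CC(C)(C)[C@H]1CC[C@]2(CC1)N=C(c1ccc(Cl)c(Cl)c1)C(=O)N2Cc1ccc(C(=O)NCCC(=O)O)cc1` gives 1600 nM
- compound 3 `CC(C)(C)CC[C@H](c1ccc(C(=O)NCCCC(=O)O)cc1)N1C(=O)C(c2cc(Cl)cc(Cl)c2)=N[C@]12CC[C@@H](C(C)(C)C)CC2` gives 350 nM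

Compound 3 gives the lowest number of the three in this assay. Compound 1 sits nearest to it, and the two values lie within the usual scatter of one another, so no order can be read between them. Compound 2 lies furthest off; its number is higher than that of compound 3 by more than the scatter allows.

The next compound, compound 4 `CC(C)(C)CC[C@H](c1ccc(C(=O)NCC(=O)O)cc1)N1C(=O)C(c2cc(Cl)cc(Cl)c2)=N[C@]12CC[C@@H](C(C)(C)C)CC2`, is to be measured in this assay. It differs from compound 3 in one place: carboxy in place of 2-carboxyethyl on a saturated chain carbon bound to an amide-type nitrogen. Within the data shown here, nothing measured so far touches this part of the molecule. Among the measured compounds shown here, the only step with a single change, a 3.1-fold higher number from compound 1 to compound 2 (0.50 log units; beyond the scatter), concerns the aryl group on the carbon with a double bond to nitrogen and says nothing about the acid-bearing chain. For the measured compounds named here, with no step bearing on the change, the expectation is that compound 4 will show no step beyond the scatter from compound 3, with a wide range to cover the uncertainty.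

The expected step is a 1.3-fold higher number from compound 3 to compound 4 (0.11 log units; within the scatter). Compound 4 is therefore estimated at 450 nM in this assay, within a range of 150 nM to 1400 nM.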

Compound 4, half-maximal inhibitory concentration: 2700 nM
Compound 4: the middle estimate sits 6.0-fold (0.78 log units) below what was measured; measured number above the stated range.
By their numbers in this assay, from the lowest: compounds 3 and 1 (each within the scatter of the next); then compounds 2 and 4 (each within the scatter of the next).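

In this assay, (carboxymethyl)carbamoyl in place of (3-carboxypropyl)carbamoyl gives a 7.7-fold higher number from compound 3 to compound 4 (0.89 log units; beyond the scatter) and so marks the acid-bearing chain as a position where the number responds to change. Among these compounds, the earlier compounds could not show this, as their only single change lay at the aryl group on the carbon with a double bond to nitrogen. Compound 3 and compound 4 differ in this chain alone, so the higher number goes with the shorter chain, although no available data give a reason for the step.

On these data alone, two chain lengths on this scaffold fix no trend, and the (2-carboxyethyl)carbamoyl chain appears only in compound 1 and compound 2, which differ from compound 3 in more than one place, so the chain length at which the number begins to rise remains open. Also open, as far as these compounds go, is whether a longer chain such as (4-carboxybutyl)carbamoyl would keep the number of compound 3 or raise it, and whether the carboxylic acid itself is needed at the chain end or an amine or primary amide could stand there.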